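Lengthening the amide chain on a shared quinone core

The source may report more compounds than this note shows. Statements on the series, on what has been measured and on what is new or still open speak of the compounds shown alone.

Measured compounds:
compound 1 `CCCCCCC(C)C(=O)NCC(C)(C)CC1=C(O)C(=O)c2ccccc2C1=O`: 23700 nM
compound 2 `CCCCCCCCC(=O)NCC(C)(C)CC1=C(O)C(=O)c2ccccc2C1=O`: 19700 nM

Among these two numbers, compound 2 carries the lowest in a functional assay on KB cells (Homo sapiens) for cytotoxicity, read by resazurin assay, with a stated time of 3 days (on this read-out lower numbers stand for stronger inhibition and higher numbers for weaker inhibition), but its nearest neighbour, compound 1, lies within the scatter of it: the one measured step, a 1.2-fold lower number from compound 1 to compound 2 (0.08 log units; within the scatter), changes the shape of the amide chain without changing its length and produces no difference beyond the noise. Compound 3 `CCCCCCCCCCCCCC(=O)NCC(C)(C)CC1=C(O)C(=O)c2ccccc2C1=O` takes the next step from compound 2: pentyl in place of hydrogen on a saturated chain carbon, eight bonds along the chain from a carbonyl carbon. Going by the values given here, no measured pair separates chains of different length, so the only guidance is that the single step, a 1.2-fold lower number from compound 1 to compound 2 (0.08 log units; within the scatter), was within the scatter. A step of similar size, in either direction, is therefore expected for this assay. For compound 3 the estimated value is 15000 nM, with a range from 5000 nM to 45000 nM. The step this estimate implies, a 1.3-fold lower number from compound 2 to compound 3 (0.12 log units; within the scatter), is expected to stay within the scatter.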

Compound 3, half-maximal inhibitory concentration: 25100 nM
For compound 3 the middle estimate is 1.7-fold (0.22 log units) below the measured one; measured number inside the range.
By their numbers in this assay, from the lowest: compounds 2, 1 and 3 (each within the scatter of the next).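

Going by these compounds alone, this is the first measured step that changes the length of the amide chain rather than its shape. In this assay, pentyl in place of hydrogen on a saturated chain carbon, eight bonds along the chain from a carbonyl carbon, gives a 1.3-fold higher number from compound 2 to compound 3 (0.11 log units; within the scatter), so this position takes a group of 5 carbon atoms with no difference beyond the noise. Nothing measured here bears on why the two chains read alike.

The compounds shown leave open whether an amine or a carboxylic acid in place of the pentyl group would give a number beyond the scatter of compound 2. Within the data shown here, they also leave open whether a longer chain than the one in compound 3 would do so.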